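Nitro in Place of Trifluoromethyl on the Shared Core

This account rests on a few compounds, and the source may have more. Where it says the series, first, only, none or still open, it means among the compounds named here.

Compound 1: `CC(=O)Nc1ccc(-c2nc3ccccc3[nH]2)cc1`; in an ADME assay on Vero cells (Chlorocebus sabaeus) for cytotoxicity (on this read-out higher numbers stand for lower toxicity in this test and lower numbers for higher toxicity in this test), compound 1 gives > 100000 nM, a limit of the assay.
Compound 2: `CC(=O)Nc1ccc(-c2nc3cc(C(F)(F)F)ccc3[nH]2)cc1`; here compound 2 gives 50000 nM.
Compound 3: `Oc1ccc(-c2nc3cc(C(F)(F)F)ccc3[nH]2)cc1`; here compound 3 gives > 100000 nM, again a limit of the assay.

Compound 2 stands alone among the measured compounds in giving a number at all in this assay; the other two values sit at the limit of > 100000 nM in this assay, at which 2 of the 3 values shown sit. Going by the values given here, the step of an at least 2.0-fold lower number from compound 1 to compound 2 (0.30 log units; that floor lies within the scatter) is the only measured change at the same position of the core, and its floor lies within the scatter. The step of an at least 2.0-fold higher number from compound 2 to compound 3 (0.30 log units; that floor lies within the scatter) touches a different part of the structure.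

Compound 4, `CC(=O)Nc1ccc(-c2nc3cc([N+](=O)[O-])ccc3[nH]2)cc1`, is not yet measured. It differs from compound 2 as follows: nitro in place of trifluoromethyl on an aromatic carbon. Among the compounds with values here, no measured step exchanges one group for another at this position, so the single step at that place, with a floor inside the scatter, gives little to lean on. Compound 4 is therefore expected to show no change at the digits printed from compound 2 to compound 4 (within the scatter), nothing beyond the scatter. Compound 4 is estimated at 50000 nM, with a range from 20000 nM to 150000 nM.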

Compound 4, half-maximal cytotoxic concentration: > 100000 nM
Compound 4 was reported as a limit; the forecaster's own chance of this, stated with the estimate: 40%; middle value at least 2.0-fold (0.30 log units) away from the limit.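

In this assay, nitro in place of trifluoromethyl gives an at least 2.0-fold higher number from compound 2 to compound 4 (0.30 log units; that floor lies within the scatter). Going by these compounds alone, this is the first exchange of one group for another at this position, and it shows that the measurable number of compound 2 does not carry over to a nitro on the same aromatic carbon, although the floor of the step does not clear the scatter. The step from compound 1 to compound 4 cannot be read, and compound 2 remains the only compound with a number: the limit of > 100000 nM in this assay, at which 3 of the 4 values shown sit.

As far as these compounds go, whether an amine, a carboxylic acid or a nitrile on this aromatic carbon would give a number rather than a limit stays open. Also open is whether hydroxy in place of acetamido would matter at all with nitro on the core, as the compounds shown test that exchange only with trifluoromethyl.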